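Replacing the chloro on a cyanopyrimidine core

The source may hold more compounds than are shown below. What is called first, only, known or untested is meant among the compounds shown, and "the series" means these compounds.

Compound 1 `N#Cc1c(Cl)nc(SCc2nc3ccccc3[nH]2)nc1-c1ccccc1` gives 3.2 nM in a functional assay on SF-268 cells (Homo sapiens) for cytotoxicity, read by MTT assay, with a stated time of 3 days; on this read-out higher numbers stand for weaker inhibition and lower numbers for stronger inhibition. Compound 2 `N#Cc1c(NN)nc(SCc2nc3ccccc3[nH]2)nc1-c1ccccc1` gives 2.77 nM, and compound 3 `CCNc1nc(SCc2nc3ccccc3[nH]2)nc(-c2ccccc2)c1C#N` gives 7.35 nM. Of these three numbers, compound 1 stands second highest; it sits within the scatter of compound 2, while compound 3 lies beyond it, as in a 2.3-fold higher number from compound 1 to compound 3 (0.36 log units; beyond the scatter). Compound 4 `N#Cc1c(NC(N)=S)nc(SCc2nc3ccccc3[nH]2)nc1-c1ccccc1` differs from compound 1 in one place: a group of 4 heavy atoms (1 carbon, 2 nitrogen, 1 sulfur; no ring) in place of one chlorine atom, on an aromatic carbon. Two measured steps replace the same chlorine with a nitrogen-bound group: a 1.2-fold lower number from compound 1 to compound 2 (0.06 log units; within the scatter) and a 2.3-fold higher number from compound 1 to compound 3 (0.36 log units; beyond the scatter). Both point to a small change at most, so compound 4 is expected to move only modestly, as in a 1.6-fold higher number from compound 1 to compound 4 (0.19 log units; within the scatter). Compound 4 is estimated to give 5 nM in this assay, within a range of 2 nM to 13 nM.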

Compound 4, half-maximal inhibitory concentration: 3.37 nM
Beside the measured number, compound 4's estimate is 1.5-fold (0.17 log units) above it, within the range that was stated.
By their numbers in this assay, from the lowest: compounds 2, 1 and 4 (each within the scatter of the next); then compound 3.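

Swapping the chloro for this larger thiourea-like group on the aromatic carbon leaves the number within the scatter, with a 1.1-fold higher number from compound 1 to compound 4 (0.02 log units; within the scatter) and likewise a 1.2-fold higher number from compound 2 to compound 4 (0.09 log units; within the scatter) in the same assay. The ethylamino compound stands apart, with a 2.2-fold lower number from compound 3 to compound 4 (0.34 log units; beyond the scatter) as the step, so among these compounds the number does not simply rise with the size of the entering group. No measurement here accounts for that difference. Still open, going by these compounds, is how a carboxylic acid, a morpholine ring or a longer chain such as butylamino would read at this position.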